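This account rests on a few compounds, and the source may have more. Where it says the series, first, only, none or still open, it means among the compounds named here.

Compound 1 `Cc1c(-c2noc(-c3ccc(OC(C)C)c(C#N)c3)n2)ccc2c1CCN(C(CO)CO)CC2` and compound 2 `Cc1c(-c2noc(-c3cnc(NC(C)C)c(C#N)c3)n2)ccc2c1CCN(C(CO)CO)CC2` share most of their structure; how their two cores differ is not broken down here. In a physicochemical assay for lipophilicity, at pH 7.4 (a lower number here means a more polar compound, a higher number a more lipophilic compound), compound 1 gives 2.64, and compound 2 gives 2.44. Compound 3 `CC(C)Oc1ccc(-c2nc(-c3ccc4c(c3)CCN(C(CO)CO)CC4)no2)cc1C#N` arises from compound 1 by a single change, (hydrogen in place of methyl on an aromatic carbon), and in this assay compound 3 gives 2.78, so that a number 0.14 log units higher from compound 1 to compound 3 (within the scatter). Compound 4 `CC(C)Nc1ncc(-c2nc(-c3ccc4c(c3)CCN(C(CO)CO)CC4)no2)cc1C#N` carries the same change made from compound 2, (hydrogen in place of methyl on an aromatic carbon), at a place described in the same words. Because a number 0.14 log units higher from compound 1 to compound 3 (within the scatter), a similar small step is expected here, estimated as a number 0.14 log units higher from compound 2 to compound 4 (within the scatter). Compound 4 is therefore estimated at 2.58 in this assay, with a likely range from 2.3 to 2.86.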

Compound 4, distribution coefficient: 2.63
Compound 4: middle estimate off by 0.05 log units, on the low side; the measured number falls inside the stated range.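

In this assay putting hydrogen in place of methyl on an aromatic carbon gives a number 0.19 log units higher from compound 2 to compound 4 (within the scatter) and, on the core of compound 1, gives a number 0.14 log units higher from compound 1 to compound 3 (within the scatter) for the same change. Neither step can be told apart from repeat-measurement noise, so these two pairs show no clear effect of the change on either core, and two pairs are too few to set a rule for the series. Nothing measured here explains the result.

Going by these compounds, it remains open whether a fluorine atom, an ethyl group or a carboxylic acid on that aromatic carbon would give a clearer step. On these data alone, how the methyl-to-hydrogen change behaves on any further core also remains open.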